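The source may hold more compounds than are shown below. What is called first, only, known or untested is meant among the compounds shown, and "the series" means these compounds.

Working notes on a set of amides sharing one core, assessed in an assay on isolated protein for inhibition of Discoidin domain-containing receptor 2 (Homo sapiens), read by ELISA, with a stated time of 60 min; a higher number here means a weaker inhibitor, a lower number a stronger inhibitor.

Three compounds carry measured numbers. Compound 1 `Cc1ccc(C(=O)Nc2cc(CN3CCN(C4CCCC4)CC3)cc(C(F)(F)F)c2)cc1-c1ccc2cn[nH]c2c1` gives 7 nM in this assay. Compound 2 `Cc1ccc(C(=O)Nc2cccc(C(F)(F)F)c2)cc1-c1ccc2c(-c3ccc(N4CCN(C)CC4)cc3)n[nH]c2c1` gives 8.8 nM in this assay. Compound 3 `CCn1cc(-c2n[nH]c3cc(-c4cc(C(=O)Nc5cccc(C(F)(F)F)c5)ccc4C)ccc23)cn1` gives 2.6 nM in this assay, the lowest of the three numbers; its gap to compound 1 and its gap to compound 2 both lie beyond the usual scatter, so compound 3 is the most potent of the three as measured here. No pair among these three differs in only one place, so no single structural step between measured compounds can be read off.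

Compound 4 `Cc1ccc(C(=O)Nc2cccc(C(F)(F)F)c2)cc1-c1ccc2c(-c3cnn(CC(=O)N(C)C)c3)n[nH]c2c1` has not yet been measured. It differs from compound 3 in one place: dimethylcarbamoyl in place of methyl on a saturated chain carbon bound to an aromatic nitrogen. The remainder of the molecule, the amide, the trifluoromethyl-bearing ring and the shared core, is unchanged.

For the measured compounds named here, no measured step of this kind exists in the set, so the expectation rests on the small size of the change and on the value of compound 3 in this assay, 2.6 nM. The change is expected to shift the number little, if at all beyond the scatter, in either direction; the step expected from compound 3 to compound 4 is a 1.5-fold higher number from compound 3 to compound 4 (0.19 log units; within the scatter). Compound 4 is estimated at 4 nM, with a range from 1.5 nM to 12 nM.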

Compound 4, half-maximal inhibitory concentration: 2.7 nM
The estimate for compound 4 lay 1.5-fold (0.17 log units) above the measured number, and the stated range covers the measured number.
By their numbers in this assay, from the lowest: compounds 3 and 4 (each within the scatter of the next); then compounds 1 and 2 (each within the scatter of the next).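

In this assay, for the compounds shown here, placing dimethylcarbamoyl in place of methyl on a saturated chain carbon bound to an aromatic nitrogen gives a 1.0-fold higher number from compound 3 to compound 4 (0.02 log units; within the scatter), the first step in the set that can be read at a single place. The entering group brings five heavy atoms against one, along with a hydrogen-bond acceptor and a double bond outside aromatic rings, yet the two numbers stand within the scatter of each other, so at this place the assay does not separate the small group from the larger one. Nothing in hand bears on why the number holds across this change.

This single step cannot say whether the tolerance extends to other groups at the same place, such as a carboxylic acid, a dimethylamine on the chain or a longer chain ending in the same amide. Steps linking compound 1 or compound 2 to this pair cannot be read, so whether the same holds on the other substitution patterns of the shared core also remains open.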